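This account rests on a few compounds, and the source may have more. Where it says the series, first, only, none or still open, it means among the compounds named here.

Compound 1 `Nc1cccc(-c2cn3nc(-c4cccs4)sc3n2)c1` in a functional assay on HeLa cells (Homo sapiens) for inhibition, read by cell counting, with a stated time of 4 days (on this read-out higher numbers stand for weaker inhibition and lower numbers for stronger inhibition), gives only a limit, > 250000 nM. Compound 2 `CCc1ccc(-c2nn3cc(-c4cccc(N)c4)nc3s2)cc1` in this assay gives 8100 nM. Compound 3 `C=C(Br)C(=O)Nc1cccc(-c2cn3nc(-c4ccc(CC)cc4)sc3n2)c1` in this assay gives 3200 nM.

Going by the values given here, compound 3 therefore holds the lowest of the two numbers; the change a 2.5-fold lower number from compound 2 to compound 3 (0.40 log units; beyond the scatter) is the only measured step. Compound 4 `C=C(Br)C(=O)Nc1cccc(-c2cn3nc(Cc4cccc(OC)c4)sc3n2)c1` differs from compound 3 by 3-methoxybenzyl in place of 4-ethylphenyl on an aromatic carbon. Among the compounds with values here, no measured step touches this position; compound 1 and compound 2 differ there, and compound 1 reaches only a limit while compound 2 gives a number, so the group at this carbon matters but its direction for compound 4 is unknown. Compound 4 is expected to show a 3.1-fold higher number from compound 3 to compound 4 (0.49 log units; beyond the scatter), with an estimate of 10000 nM and a range from 2000 nM to 100000 nM.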

Compound 4, half-maximal inhibitory concentration: 2500 nM
For compound 4 the middle estimate is 4.0-fold (0.60 log units) above the measured one; measured number inside the range.
By their numbers in this assay, from the lowest: compounds 4 and 3 (each within the scatter of the next); then compound 2. At a limit, above all of these: compound 1.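

In this assay, going by these compounds alone, 3-methoxybenzyl in place of 4-ethylphenyl gives a 1.3-fold lower number from compound 3 to compound 4 (0.11 log units; within the scatter), the first step at this aromatic carbon that can be read as numbers on both sides. These two different groups therefore leave the read-out within the usual scatter. Compound 1, which differs from compound 2 only at this carbon, gives only a limit: the limit of > 250000 nM in this assay, at which 1 of the 4 values shown sits.

From the compounds shown here alone, it remains open whether a benzyl group carrying an amine or a carboxylic acid would fit this carbon equally well. Going by these compounds, it is also open how 3-methoxybenzyl behaves with the free aromatic amine of compound 2 in place of the (1-bromoethenyl)carbonyl amide.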